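A few compounds are considered here, and "the series" means these few. Any claim that something is new, unique, unknown or untested is made for them only; others in the source may bear on it.

In an ADME assay on MT4 cells (Homo sapiens) for cytotoxicity, read by MTT assay (a lower number here means that less compound is tolerated, a higher number that more compound is tolerated), three compounds have been measured so far:

compound 1 `Cc1ccccc1C(=O)N(C(=S)OCCN1C(=O)c2ccccc2C1=O)c1ccc(Cl)cc1` gives 21000 nM
compound 2 `O=C1c2ccccc2C(=O)N1CCOC(=S)N(C(=O)c1ccc(Br)cc1)c1ccc(Br)cc1` gives 73000 nM
compound 3 `O=C1c2ccccc2C(=O)N1CCOC(=S)N(C(=O)c1ccc(Cl)c([N+](=O)[O-])c1)c1ccccc1` gives 51000 nM

Compound 1 has the lowest of these three numbers, so the cells tolerate less of it than of compound 3 or compound 2; both gaps lie beyond the usual scatter. Compound 4 `O=C1c2ccccc2C(=O)N1CCOC(=S)N(C(=O)c1cc(F)ccc1F)c1ccc(Cl)cc1` keeps the shared core of compound 1 and differs in one place: 2,5-difluorophenyl in place of 2-methylphenyl on a carbonyl carbon. For the measured compounds named here, no measured pair shows this change, so nothing here fixes its size. The step from compound 1 to compound 4 in this assay is expected to be small, a 1.2-fold higher number from compound 1 to compound 4 (0.09 log units; within the scatter), likely within the scatter, with a slight lean toward a higher number. Compound 4 is therefore estimated at 26000 nM, with a range from 11000 nM to 65000 nM.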

Compound 4, half-maximal cytotoxic concentration: 54000 nM
Compound 4: the middle estimate sits 2.1-fold (0.32 log units) below what was measured, and the stated range covers the measured number.
By their numbers in this assay, from the lowest: compound 1; then compounds 3, 4 and 2 (each within the scatter of the next).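

Putting 2,5-difluorophenyl in place of 2-methylphenyl on a carbonyl carbon gives, in this assay, a 2.6-fold higher number from compound 1 to compound 4 (0.41 log units; beyond the scatter). For the compounds shown here, this is the first measured step at this position, and it shows that a change here alone can move the number beyond the scatter. Nothing available accounts for this step.

As far as these compounds go, it remains open whether a phenyl ring carrying a single fluorine would give a similar step. From the compounds shown here alone, it is also open how an amine or a carboxylic acid on this ring would read.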